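Moving a Hydroxyl Group Across Two Related Cores

The source may hold more compounds than are shown below. What is called first, only, known or untested is meant among the compounds shown, and "the series" means these compounds.

Compound 1 `Oc1ccc(-c2cc(-c3ccsc3)cc(-c3cccc(O)c3)n2)cc1` and compound 2 `Oc1ccc(-c2cc(-c3ccsc3)cc(-c3ccc(O)cc3)n2)cc1` share one core. In a functional assay on HCT-15 cells (Homo sapiens) for cytotoxicity, read by CCK-8 assay (on this read-out higher numbers stand for weaker inhibition and lower numbers for stronger inhibition), compound 1 gives 1180 nM and compound 2 gives 1040 nM, a step of a 1.1-fold lower number from compound 1 to compound 2 (0.05 log units; within the scatter) for (4-hydroxyphenyl in place of 3-hydroxyphenyl on an aromatic carbon). Compound 3 `Oc1cccc(-c2cc(-c3cccnc3)cc(-c3ccccc3O)n2)c1` sits on another core; the difference between the two cores is not broken down here. In this assay compound 3 gives 8280 nM. Compound 4 `Oc1ccc(-c2cc(-c3cccnc3)cc(-c3ccccc3O)n2)cc1` arises from compound 3 by the same kind of change, (4-hydroxyphenyl in place of 3-hydroxyphenyl on an aromatic carbon), though the surroundings differ: in compound 1 the site is meta to a 4-hydroxyphenyl group and meta to a thiophen-3-yl group, in compound 3 meta to a 2-hydroxyphenyl group and meta to a pyridin-3-yl group. For compound 4 an expected step of a 1.1-fold lower number from compound 3 to compound 4 (0.04 log units; within the scatter) is assumed, resting on the step of a 1.1-fold lower number from compound 1 to compound 2 (0.05 log units; within the scatter) that lay within the scatter. Compound 4 is therefore estimated at 7500 nM, between 3500 nM and 16000 nM.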

Compound 4, half-maximal inhibitory concentration: > 50000 nM
Compound 4 gave a limit, no number; the forecaster's own chance of this, stated with the estimate: 5%; middle value at least 6.6-fold (0.82 log units) away from the limit.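

In this assay compound 4 gives > 50000 nM, which is a limit of the assay and not a number. Putting 4-hydroxyphenyl in place of 3-hydroxyphenyl gives an at least 6.0-fold higher number from compound 3 to compound 4 (0.78 log units; beyond the scatter), so the change does not carry over unaltered from the core of compound 1 to the core of compound 3: the same change on two cores in this assay, a 1.1-fold lower number (0.05 log units; within the scatter) from compound 1 to compound 2 and an at least 6.0-fold higher number (0.78 log units; beyond the scatter) from compound 3 to compound 4, at least 6.8-fold (0.83 log units) apart, beyond the scatter of two such steps. Among the compounds shown here, with only two pairs, this does not show which difference between the cores matters, the thiophen-3-yl against the pyridin-3-yl group or the 4-hydroxyphenyl against the 2-hydroxyphenyl group, and the full size of the step stays unknown.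

The compounds shown leave open how the step behaves on a core that differs in only one of these groups. They also leave open what an amine or a methoxy group would do in place of the hydroxyl group.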